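The source may hold more compounds than are shown below. What is called first, only, known or untested is meant among the compounds shown, and "the series" means these compounds.

Measured in a functional assay on Raji cells (Homo sapiens) for cytotoxicity, with a stated time of 72 h; a higher number here means that more compound is needed for the effect, a lower number that less compound is needed:
Compound 1 `C=C[C@@](C)(/C=C/c1ccc(Nc2ccc(F)c(F)c2)cc1)CCC=C(C)C`: > 26000 nM, a limit of the assay
Compound 2 `C=C[C@@](C)(/C=C/c1ccc(Nc2ccc(Cl)c(F)c2)cc1)CCC=C(C)C`: > 26000 nM, a limit of the assay

Among the compounds with values here, compound 2 has no number in this assay, only a limit, and the one other value shown is also a limit. The two compounds share the same position: the limit of > 26000 nM in this assay, at which 2 of the 2 values shown sit. The change that links them is chloro in place of fluoro on an aromatic carbon, and it gives a step that the two limits leave unreadable from compound 1 to compound 2.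

Compound 3 `C=C[C@@](C)(/C=C/c1ccc(Nc2cc(F)c(F)cc2F)cc1)CCC=C(C)C` differs from compound 2 on the aniline side of the shared core: 2,4,5-trifluorophenyl in place of 4-chloro-3-fluorophenyl on a nitrogen on an aromatic ring. In words, this is 2,4,5-trifluorophenyl in place of 4-chloro-3-fluorophenyl on a nitrogen on an aromatic ring.

Within the data shown here, no measured step of readable size bears on this change, so the data offer no basis for expecting a move in either direction. The expectation rests on compound 1 and compound 2, which both sit at the limit of > 26000 nM in this assay, at which 2 of the 2 values shown sit. Compound 3 is therefore expected to remain at the same limit, with no step beyond the scatter. The step expected is a number no higher from compound 2 to compound 3 (the limit leaves the size open). Compound 3 is estimated at 26000 nM, with an expected range from 13000 nM to 40000 nM.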

Compound 3, half-maximal effective concentration: > 26000 nM
Compound 3 gave a limit, no number (the forecaster's own chance of this, stated with the estimate: 85%); the middle value sits exactly at the limit.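

In this assay compound 3 gives > 26000 nM as a limit of the assay and not a number. No new step can be read among compound 1, compound 2 and compound 3, which share one position: the limit of > 26000 nM in this assay, at which 3 of the 3 values shown sit. The compounds shown leave open whether any of these changes on the shared core alters the read-out at all.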